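A few compounds are considered here, and "the series" means these few. Any claim that something is new, unique, unknown or untested is made for them only; others in the source may bear on it.

Measured so far:
compound 1 `N#Cc1cc(Cl)cc(Oc2c(Cl)ccc3c2nnn3Cc2n[nH]c3nc(N)ccc23)c1`: 11.9 mL/min/kg
compound 2 `N#Cc1cc(Cl)cc(Oc2c(Cl)ccc3c2cnn3Cc2n[nH]c3ncccc23)c1`: 18 mL/min/kg

In an in vivo ADME assay on the whole organism (plasma, strain Sprague-Dawley) for pharmacokinetics, with Rattus norvegicus as the target (a higher number here means faster removal of the compound, a lower number slower removal), compound 2 gives 18 mL/min/kg; compound 1 gives 11.9 mL/min/kg, and the two numbers lie within the scatter of each other, so compound 2 stands apart from compound 1 in no way this assay can tell. Compound 3 `N#Cc1cc(Cl)cc(Oc2c(Cl)ccc3c2cnn3Cc2n[nH]c3nc(N)ccc23)c1` is not yet measured. It differs from compound 2 by amino in place of hydrogen on an aromatic carbon. Within the data shown here, no step between measured compounds covers this change. In this assay the step from compound 2 to compound 3 is expected to be a 1.4-fold lower number from compound 2 to compound 3 (0.14 log units; within the scatter), nothing beyond the scatter, leaning if anywhere toward a lower number because compound 1 gives 11.9 mL/min/kg while carrying amino. Compound 3 is therefore estimated at 13 mL/min/kg, within 7 mL/min/kg to 24 mL/min/kg.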

Compound 3, clearance in the Rattus norvegicus assay: 4.7 mL/min/kg
Compound 3: middle estimate off by 2.8-fold (0.44 log units), on the high side; the whole stated range lies above it.
By their numbers in the Rattus norvegicus assay, from the lowest: compound 3; then compounds 1 and 2 (each within the scatter of the next).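

Among these compounds, in the Rattus norvegicus assay, amino in place of hydrogen on an aromatic carbon, next to the ring nitrogen, gives a 3.8-fold lower number from compound 2 to compound 3 (0.58 log units; beyond the scatter), the first single-change step and one beyond the scatter. In a physicochemical assay for solubility, at pH 2 (on this read-out higher numbers stand for higher solubility and lower numbers for lower solubility), compound 2 gives < 0.1 ug/mL, which is a limit of the assay. In the physicochemical assay compound 3 gives 40 ug/mL, a measured number for the same single change.

Going by these compounds, whether a methylamino or a hydroxyl group at this place would give similar numbers stays open. So does whether the two read-outs move together beyond this one pair.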